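Amide-end variation at the oxo-amide terminus

The compounds below may be only part of what the source reports. "The series", "measured", "known", "first", "only" and "open" are said of these compounds alone.

Measured so far:
- compound 1, `CCCC[C@H](NC(=O)O[C@H](Cn1cnc(-c2ccc(C(F)(F)F)cc2)c1)C(C)(C)C)C(=O)C(=O)Nc1ccn[nH]1`: in an in vivo ADME assay on the whole organism (Rattus norvegicus) for pharmacokinetics (on this read-out higher numbers stand for a longer-lived compound and lower numbers for a shorter-lived compound), compound 1 gives 7.67 h
- compound 2, `CCCC[C@H](NC(=O)O[C@H](Cn1ccc(-c2ccc(C(F)(F)F)cc2)n1)C(C)(C)C)C(=O)C(=O)Nc1ccccn1`: in this assay compound 2 gives 3.5 h

Compound 2 holds the lower of the two numbers in this assay; compound 1 sits higher by a margin beyond the usual scatter. For the measured compounds named here, the two structures differ at more than one site, so no single step is counted between them and the gap cannot be tied to one change.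

Compound 3, `CCCC[C@H](NC(=O)O[C@H](Cn1ccc(-c2ccc(C(F)(F)F)cc2)n1)C(C)(C)C)C(=O)C(=O)NCc1ccno1`, follows from compound 2 by one change: (1,2-oxazol-5-yl)methyl in place of pyridin-2-yl on an amide-type nitrogen. Going by the values given here, no measured pair isolates this change, and the only other compound with a different group on that nitrogen, compound 1, also carries a different core. The expectation therefore rests on compound 2 alone. In this assay compound 3 is expected near 3 h, within a range from 1.2 h to 7.5 h. The expected step of a 1.2-fold lower number from compound 2 to compound 3 (0.07 log units; within the scatter) is a small move downward, not beyond the usual scatter in either direction, with the wide range reflecting that no comparable change has yet been measured in this series.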

Compound 3, half-life: 6.67 h
Estimate against measurement, compound 3: 2.2-fold (0.35 log units) below; the measured number falls inside the stated range.
By their numbers in this assay, from the lowest: compounds 2, 3 and 1 (each within the scatter of the next, the first and the last beyond it).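

In this assay, for the compounds shown here, the exchange of pyridin-2-yl for (1,2-oxazol-5-yl)methyl on the amide-type nitrogen, with the rest of the structure held constant, gives a 1.9-fold higher number from compound 2 to compound 3 (0.28 log units; within the scatter) and is the first step that isolates this position. The change is not a small one in structural terms: a six-membered aromatic ring with 1 hetero atom gives way to a five-membered aromatic ring with 2 hetero atoms, and that ring is now held on the nitrogen through a methyl group, yet the two half-lives remain within the scatter of each other, so this pair shows no separation at this position. No measured data on the compounds bear on what lies behind this result.

A single step cannot show whether the position stays this insensitive to other groups, such as a plain benzyl, an aminoethyl chain or a chain ending in a carboxylic acid. As far as these compounds go, it also remains open whether (1,2-oxazol-5-yl)methyl gives a similar half-life on the core of compound 1, which would allow the contribution of the core to be read on its own.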